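From furan-3-yl to ethynyl on the shared core

A few compounds are considered here, and "the series" means these few. Any claim that something is new, unique, unknown or untested is made for them only; others in the source may bear on it.

In a functional assay on CEM-DNR-bulk cells (Homo sapiens), read by MTT assay, with a stated time of 72 h (on this read-out higher numbers stand for weaker inhibition and lower numbers for stronger inhibition), compound 2 (`CSc1ncnc2c1c(-c1ccoc1)cn2[C@@H]1O[C@H](CO)[C@@H](O)[C@H]1O`) gives > 20000 nM as a limit and not a number. Compound 3 (`CSc1ncnc2c1c(-c1ccsc1)cn2[C@@H]1O[C@H](CO)[C@@H](O)[C@H]1O`) gives > 20000 nM as a limit as well. Compound 1 (`COc1ncnc2c1c(-c1ccccc1)cn2[C@@H]1O[C@H](CO)[C@@H](O)[C@H]1O`) likewise gives > 20000 nM as a limit. All three therefore sit at one boundary, summed up as the limit of > 20000 nM in this assay, at which 3 of the 3 values shown sit, in this series.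

Compound 4 (`C#Cc1cn([C@@H]2O[C@H](CO)[C@@H](O)[C@H]2O)c2ncnc(SC)c12`) departs from compound 2 at a single place, as ethynyl in place of furan-3-yl on an aromatic carbon shows. Within the data shown here, the only measured step is a step that the two limits leave unreadable from compound 2 to compound 3 and it offers no size to carry over. Neither the size nor the direction of the new step can be read from the data. The entering ethynyl has no ring, unlike the groups measured so far, so a number under the limit remains possible, though another limit is nearly as likely.

For compound 4 the expected value is 8000 nM within an estimated range of 1000 nM to 20000 nM on this read-out. This estimate implies an expected at least 2.5-fold lower number from compound 2 to compound 4 (0.39 log units; beyond the scatter) toward stronger inhibition, with its size uncertain.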

Compound 4, half-maximal inhibitory concentration: 110 nM
Compound 4: the middle estimate sits 73-fold (1.86 log units) above what was measured, outside the stated range (below it).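

In this assay, the results show that this aromatic carbon of the shared core can carry strong inhibition, with the group placed there deciding the outcome: ethynyl gives an at least 180-fold lower number from compound 2 to compound 4 (2.25 log units; beyond the scatter), and it gives an at least 180-fold lower number from compound 3 to compound 4 (2.25 log units; beyond the scatter). Among these compounds, the step between the two ring-bearing compounds, furan-3-yl and thiophen-3-yl, cannot be read, so the earlier compounds showed no effect of the group at this place. Ethynyl, which has no ring and a triple bond, is the only group shown to yield a number rather than a limit: the limit of > 20000 nM in this assay, at which 3 of the 4 values shown sit.

As far as these compounds go, it remains open whether the triple bond itself matters or only the loss of a ring, a question that an ethyl group, a nitrile or a chlorine atom on this carbon could address. From the compounds shown here alone, whether a longer alkyne such as propynyl would hold the value is also open.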